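Compound 3: azetidinyl ether in place of cyclopropyl ether

A few compounds are considered here, and "the series" means these few. Any claim that something is new, unique, unknown or untested is made for them only; others in the source may bear on it.

In a functional assay on HCT-116 cells (Homo sapiens) for antiproliferative activity, read by MTT assay, with a stated time of 48 h (a higher number here means a weaker inhibitor, a lower number a stronger inhibitor), compound 1 `COc1cc(-c2nnc3c(OC)cc(-c4ccc5[nH]ccc5c4)cn23)cc(OC)c1OC` gives 108 nM. Within the data shown here, compound 2 `COc1cc(-c2nnc3c(OC4CC4)cc(-c4ccc5[nH]ccc5c4)cn23)cc(OC)c1OC` gives 275 nM, the higher of the two numbers measured so far, which makes it the weaker inhibitor of the pair.

Compound 3 `COc1cc(-c2nnc3c(OC4CN(C(C)(C)C)C4)cc(-c4ccc5[nH]ccc5c4)cn23)cc(OC)c1OC` carries 1-(tert-butyl)azetidin-3-yl in place of cyclopropyl on an oxygen on an aromatic ring. The rest of the structure matches compound 2.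

Among the measured compounds shown here, only one measured step bears on this change, since it sits at the same oxygen: a 2.5-fold higher number from compound 1 to compound 2 (0.41 log units; beyond the scatter). That step is modest but beyond the scatter. For the measured compounds named here, a single step does not establish a trend, and no measured compound yet carries an azetidine ring, so the direction is tentative and the range is kept wide.

A further modest move towards a higher number is expected in this assay, with the estimated step being a 2.4-fold higher number from compound 2 to compound 3 (0.37 log units; beyond the scatter). Compound 3 is estimated at 650 nM, with an expected range of 200 nM to 2000 nM.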

Compound 3, half-maximal inhibitory concentration: > 10000 nM
Compound 3: only a limit was reported (the forecaster's own chance of this, stated with the estimate: 3%); middle value at least 15-fold (1.18 log units) from the limit.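

In this assay, 1-(tert-butyl)azetidin-3-yl in place of cyclopropyl on this oxygen gives an at least 36-fold higher number from compound 2 to compound 3 (1.56 log units; beyond the scatter), and the same group in place of methyl gives an at least 92-fold higher number from compound 1 to compound 3 (1.96 log units; beyond the scatter), so a position that had shifted only modestly between two small groups now separates the compounds sharply. Compound 3 is reported only as a limit, and both steps are therefore minimum sizes: the limit of > 10000 nM in this assay, at which 1 of the 3 values shown sits. Across compound 1, compound 2 and compound 3, the number rises with the heavy-atom count of the group on the oxygen and none of the three goes against this, although three compounds are a thin basis for a trend.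

The compounds shown do not separate the azetidine ring from its tert-butyl group, so the useful comparisons would be a cyclobutyl ether and an azetidin-3-yl ether with a hydrogen or a methyl on the ring nitrogen. Going by these compounds, it also remains open whether a longer chain ending in an amine, such as a 2-(dimethylamino)ethyl ether, would read closer to compound 2 or to compound 3.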